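Naphthalen-2-yl in place of ethyl on a fused core

The compounds below may be only part of what the source reports. "The series", "measured", "known", "first", "only" and "open" are said of these compounds alone.

Compound 1 `CCc1nc2sccn2c1/C=N/OCc1ccc(Cl)c(Cl)c1` carries an ethyl group on its fused two-ring core. In an assay on HepG2 cells for agonist activity at nuclear receptor subfamily 1 group I member 3 (Homo sapiens), read by a luciferase reporter, with a stated time of 23 h (on this read-out lower numbers stand for an effect already at smaller amounts and higher numbers for an effect only at larger amounts of compound), compound 1 gives 2600 nM. Compound 2 `CC(C)(C)c1ccc(CO/N=C/c2c(-c3ccc4ccccc4c3)nc3occn23)cc1` gives 7900 nM, a number reported as beyond the usual scatter from that of compound 1, so compound 1 stands lower of the two numbers. Compound 3 `C(=N/OCc1ccc(Oc2ccccc2)cc1)\c1c(-c2ccc3ccccc3c2)nc2occn12` gives "not active" (no number reported), a read-out with no number attached. Among the compounds with values here, compound 1 therefore holds the lowest number among the compounds measured so far.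

Compound 4 `Clc1ccc(CO/N=C/c2c(-c3ccc4ccccc4c3)nc3sccn23)cc1Cl` is the next compound to be measured. It differs from compound 1 in one place: naphthalen-2-yl in place of ethyl on an aromatic carbon. Within the data shown here, the two compounds that already carry naphthalen-2-yl, compound 2 and compound 3, sit on a core that is not the core of compound 1 and bear other groups on the benzyl part, so no step between measured compounds shows this change by itself. Still, the higher number of compound 2 and the absence of a number for compound 3 point toward a larger number for compound 4 than for compound 1. The step from compound 1 to compound 4 is expected to be an increase, with a size of a 1.9-fold higher number from compound 1 to compound 4 (0.28 log units; within the scatter), and compound 4 is estimated at 5000 nM with a range from 1500 nM to 20000 nM.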

Compound 4, half-maximal effective concentration: 380 nM
Beside the measured number, compound 4's estimate is 13-fold (1.12 log units) above it; the whole stated range lies above it.
By their numbers in this assay, from the lowest: compound 4; then compound 1; then compound 2.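

Exchanging ethyl for naphthalen-2-yl, on an aromatic carbon of a five-membered aromatic ring with 2 nitrogen, brings a 6.8-fold lower number from compound 1 to compound 4 (0.84 log units; beyond the scatter) in this assay, with the larger group standing where the smaller one stood. The earlier compounds shown here that carry naphthalen-2-yl differ from compound 1 in more than one place, so they could not show this change by itself; this single step shows that, on the core of compound 1 and with the benzyl part held the same, a group of 10 heavy atoms at this position goes with a lower number than one of 2 heavy atoms. The compounds shown give no measurement that accounts for this drop.

On these data alone, it remains open whether a single phenyl ring or a longer alkyl chain such as butyl would give a number closer to that of the ethyl or the naphthalen-2-yl compound at this position. As far as these compounds go, it also remains open whether the same exchange would give a step of similar size on the core shared by compound 2 and compound 3.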